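Swapping an aryl for a sulfonyl on a piperazine

The source may hold more compounds than are shown below. What is called first, only, known or untested is meant among the compounds shown, and "the series" means these compounds.

Compound 1, `O=C(/C=C/c1ccccc1)c1ccc(N2CCN(c3ccccc3Cl)CC2)cc1`, was tested in a functional assay on the whole organism (strain Kunming) for inhibition, with Mus musculus as the target, with a stated time of 1 h, at a dose of 40 mg/kg by the oral route (a lower number here means less inhibition, a higher number more inhibition at the dose given (going by the name of the read-out)), where compound 1 gives 4.71%. Going by the values given here, of the two compounds measured so far this is the lower number; the other, compound 2, `O=C(/C=C/c1ccc(Cl)cc1)c1ccc(N2CCN(S(=O)(=O)c3ccc(Cl)cc3)CC2)cc1`, gives 56.6%, a gap that lies beyond the usual scatter of repeated runs. Compound 2 also carries a sulfonyl-linked ring on the ring nitrogen and chlorine atoms on both outer rings, so it does not differ from compound 1 in one place only.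

Compound 3, `O=C(/C=C/c1ccccc1)c1ccc(N2CCN(S(=O)(=O)c3ccccc3)CC2)cc1`, has not been measured. It differs from compound 1 in a single place: phenylsulfonyl in place of 2-chlorophenyl on an amine nitrogen in a ring. Compound 2 shows that a sulfonyl-linked ring on that nitrogen can go together with a much higher number than compound 1 shows, so the step from compound 1 to compound 3 is expected to be upward and beyond the scatter, a number 30.3 percentage points higher from compound 1 to compound 3 (beyond the scatter). The expected value for compound 3 is 35%, with a range from 10% to 60%.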

Compound 3, a percentage reported as inhibition, in the whole organism at one dose (the size of the read-out at that dose, not a potency): 30%
For compound 3 the middle estimate is 5 percentage points above the measured one; measured number inside the range.
By their numbers in this assay, from the lowest: compound 1; then compound 3; then compound 2.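

Going by these compounds alone, this is the first comparison here in which only one place changes: on the amine nitrogen in the ring, phenylsulfonyl in place of 2-chlorophenyl gives, in this assay, a number 25.3 percentage points higher from compound 1 to compound 3 (beyond the scatter). So this position responds to the choice of group, and the higher number needs no chlorine on either outer ring, since compound 3 carries none. Nothing shown accounts for the rise.

The swap removes the chlorine and adds the sulfonyl link in a single step, so the contribution of each remains unresolved. A plain phenyl group on that nitrogen would help separate the two, while a benzoyl or methylsulfonyl group would test whether the link or the ring it carries matters more.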